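A few compounds are considered here, and "the series" means these few. Any claim that something is new, unique, unknown or untested is made for them only; others in the source may bear on it.

Measured compounds:
- Compound 1 `CN(C)C(=O)N1CCN(S(=O)(=O)N2CC=C(c3ccc(F)cc3)CC2)[C@@H](C(=O)NO)C1`: in a functional assay on MONO-MAC-6 cells (Homo sapiens) for inhibition (a higher number here means a weaker inhibitor, a lower number a stronger inhibitor), compound 1 gives 200 nM.
- Compound 2 `O=C(NO)[C@H]1CN(C(=O)N2CCOCC2)CCN1S(=O)(=O)N1CC=C(c2ccc(F)cc2)CC1`: in this assay compound 2 gives 350 nM.

Among these two numbers compound 2 stands highest, with compound 1 as its only neighbour; the step of a 1.8-fold higher number from compound 1 to compound 2 (0.24 log units; within the scatter) is small, so the two compounds cannot be told apart on these data.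

Compound 3 `CN(C)S(=O)(=O)N1CCN(S(=O)(=O)N2CC=C(c3ccc(F)cc3)CC2)[C@@H](C(=O)NO)C1` differs from compound 2 in one place: dimethylsulfamoyl in place of (morpholin-4-yl)carbonyl on an amine nitrogen in a ring.

For the measured compounds named here, only one measured step exists, a 1.8-fold higher number from compound 1 to compound 2 (0.24 log units; within the scatter), and it swaps two amine groups on a carbonyl carbon. Going by the values given here, the change to compound 3 instead replaces the whole (morpholin-4-yl)carbonyl with a dimethylsulfamoyl, so no measured step shows the same kind of exchange. Among the compounds with values here, with the single step seen lying within the scatter, a step of about a 1.2-fold lower number from compound 2 to compound 3 (0.07 log units; within the scatter) is expected, in no particular direction. For compound 3 the estimate in this assay is 300 nM, with a range from 120 nM to 750 nM.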

Compound 3, half-maximal inhibitory concentration: 250 nM
Estimate against measurement, compound 3: 1.2-fold (0.08 log units) above; measured number inside the range.
By their numbers in this assay, from the lowest: compounds 1, 3 and 2 (each within the scatter of the next).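

At the amine nitrogen in the ring, dimethylsulfamoyl takes the place of a group joined through a carbonyl, and in this assay the number stays within the scatter of both carbonyl-linked compounds, whether the group replaced is (morpholin-4-yl)carbonyl (a 1.4-fold lower number from compound 2 to compound 3 (0.15 log units; within the scatter)) or dimethylcarbamoyl (a 1.3-fold higher number from compound 1 to compound 3 (0.10 log units; within the scatter)). The earlier compounds shown here varied only what sits on the carbonyl; this result shows that exchanging the carbonyl link itself also gives a number that cannot be told apart from the others. No measurement is available that would explain why these three groups read alike.

As far as these compounds go, all three groups are uncharged and of similar kind, so it remains open whether a group carrying a basic amine or a carboxylic acid at this nitrogen would shift the number beyond the scatter. From the compounds shown here alone, a longer alkyl chain on the sulfamoyl nitrogen is an equally open case.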